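Anilino to cyclopropylamino on the shared core

This account rests on a few compounds, and the source may have more. Where it says the series, first, only, none or still open, it means among the compounds named here.

Within the data shown here, compound 2 `Cc1cc(Cl)ccc1NC(=O)Nc1nc(Nc2ccccc2)cc(Sc2c[nH]c3ccccc23)n1` is one of two compounds measured in a functional assay on HepG2 cells (Homo sapiens) for inhibition, with a stated time of 72 h; a lower number here means a stronger inhibitor, a higher number a weaker inhibitor. In this assay compound 2 gives 8370 nM, the lowest of the two numbers; the other is compound 1 `Cc1ccc(NC(=O)Nc2nc(Nc3ccccc3)cc(Sc3c[nH]c4ccccc34)n2)cc1`, which in this assay gives 14900 nM. Among the measured compounds shown here, the only measured step, a 1.8-fold lower number from compound 1 to compound 2 (0.25 log units; within the scatter), changes the group on the amide-type nitrogen and stays within the scatter, so the two values cannot be ordered against each other.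

Compound 3 `Cc1cc(Cl)ccc1NC(=O)Nc1nc(NC2CC2)cc(Sc2c[nH]c3ccccc23)n1` differs from compound 2 by cyclopropyl in place of phenyl on a nitrogen on an aromatic ring. For the measured compounds named here, no measured step touches this nitrogen; the step from compound 1 to compound 2 sits elsewhere on the shared core and gives no guide to the size or direction of this change. With nothing to rest on beyond the values of compound 2 and compound 1, the step in this assay is expected to stay within the scatter, a 1.2-fold higher number from compound 2 to compound 3 (0.08 log units; within the scatter), with a wide range to either side. For compound 3 the estimate in this assay is 10000 nM, expected to fall between 3000 nM and 40000 nM.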

Compound 3, half-maximal inhibitory concentration: 9740 nM
Estimate against measurement, compound 3: 1.0-fold (0.01 log units) above; the range from low to high includes it.
By their numbers in this assay, from the lowest: compounds 2, 3 and 1 (each within the scatter of the next).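

Among these compounds, the anilino to cyclopropylamino exchange gives the first measurement at this nitrogen on an aromatic ring: in this assay there is a 1.2-fold higher number from compound 2 to compound 3 (0.07 log units; within the scatter). On this pair, an aromatic ring on this nitrogen is therefore not needed to keep the number within the scatter of compound 2, since the three-membered non-aromatic ring of cyclopropyl stands in place of the six-membered aromatic ring of phenyl and the two values cannot be ordered. No measured evidence bears on this result.

Going by these compounds, it remains open whether any group on this nitrogen moves the number beyond the scatter, for instance a longer alkyl chain, a morpholine ring or a chain ending in a carboxylic acid. On these data alone, it also remains open whether cyclopropyl in place of phenyl reads the same when the amide-type nitrogen carries the 4-methylphenyl group of compound 1 rather than the 4-chloro-2-methylphenyl group of compound 2.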